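The source may hold more compounds than are shown below. What is called first, only, known or untested is meant among the compounds shown, and "the series" means these compounds.

Compound 1 `CCCOC(=O)C1=C(C)NC(=O)NC1c1ccsc1` gives 44%.
Compound 2 `CC1=C(C(=O)OC2CCC2)C(c2ccco2)NC(=O)N1` gives 19%.
Compound 3 `CCC(CC)OC(=O)C1=C(C)NC(=O)NC1c1ccsc1` gives 22%.

All three were tested in an assay on membranes from CHO cells for displacement of a labelled ligand from adenosine receptor A1 (Homo sapiens), read by scintillation counting, with a stated time of 60 min, tested at 1 uM; a lower number here means less inhibition, a higher number more inhibition at the concentration tested (going by the name of the read-out). Compound 3 stands second highest of the three: its nearest neighbour is compound 2, whose value lies within the scatter of compound 3, while compound 1 stands beyond the scatter above it. Compound 4 `CC1=C(C(=O)OC2CCC2)C(c2ccsc2)NC(=O)N1` has not yet been measured. It differs from compound 3 in one place: cyclobutyl in place of pentan-3-yl on an oxygen next to a carbonyl group. Among the measured compounds shown here, only one measured step concerns the group on the oxygen next to the carbonyl group, namely a number 22 percentage points lower from compound 1 to compound 3 (beyond the scatter), where ethyl replaced hydrogen on that chain. Compound 4 moves the other way, to a group with fewer heavy atoms, and compound 2, which carries the same cyclobutyl on a different core, gives a value close to that of compound 3. In this assay a small rise or no step beyond the scatter is therefore expected. The estimate for compound 4 is 28%, between 10% and 48%, meaning an expected step of a number 6 percentage points higher from compound 3 to compound 4 (within the scatter).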

Compound 4, a percentage reported as inhibition, at one concentration (the size of the read-out at that concentration, not a potency): 40%
Estimate against measurement, compound 4: 12 percentage points below, and the stated range covers the measured number.
By their numbers in this assay, from the lowest: compounds 2 and 3 (each within the scatter of the next); then compounds 4 and 1 (each within the scatter of the next).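

In this assay the group on the oxygen next to a carbonyl group clearly matters on the shared core: cyclobutyl in place of pentan-3-yl gives a number 18 percentage points higher from compound 3 to compound 4 (beyond the scatter), so a ring here recovers what pentan-3-yl loses. Cyclobutyl in place of propyl gives a number 4 percentage points lower from compound 1 to compound 4 (within the scatter), which means these two groups cannot be told apart in this assay, and pentan-3-yl alone stands apart among the three. Thiophen-3-yl in place of furan-2-yl on a saturated ring carbon gives a number 21 percentage points higher from compound 2 to compound 4 (beyond the scatter), so cyclobutyl on its own does not hold the number down, and the two rings on that carbon also count.

No supporting data explain any of these differences. From the compounds shown here alone, whether a longer chain such as hexyl, or a larger ring such as cyclohexyl, would keep the number on that oxygen remains open.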